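The source may report more compounds than this note shows. Statements on the series, on what has been measured and on what is new or still open speak of the compounds shown alone.

Measured so far in a functional assay on L1210 cells (Mus musculus), read by MTT assay; on this read-out lower numbers stand for stronger inhibition and higher numbers for weaker inhibition:

Compound 1 `C#C[C@@]1(O)[C@H](O)[C@@H](CO)O[C@H]1n1ccc(N)nc1=O`; in this assay compound 1 gives only a limit, > 350000 nM.
Compound 2 `C#C[C@]1(O)[C@H](O)[C@@H](CO)O[C@H]1n1ccc(N)nc1=O`; in this assay compound 2 gives only a limit, > 350000 nM.
Compound 3 `O=c1ccn([C@@H]2O[C@H](CO)[C@](O)(C3CC3)[C@H]2O)c(=O)[nH]1`; in this assay compound 3 gives only a limit, > 350000 nM.

Compound 3 therefore stands at the same limit as every other value shown, and no ranking against compound 1 or compound 2 is possible from these numbers. For the measured compounds named here, the single step between measured compounds, a step that the two limits leave unreadable from compound 1 to compound 2, cannot be sized because the limit of > 350000 nM in this assay, at which 3 of the 3 values shown sit, leaves both of its ends unread; the pair is tied only by the fact that compounds 1 and 2 differ only in the configuration as drawn.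

Compound 4 `CC#C[C@@]1(O)[C@@H](CO)O[C@@H](n2ccc(=O)[nH]c2=O)[C@@H]1O` carries prop-1-yn-1-yl in place of cyclopropyl on a saturated ring carbon. Going by the values given here, no measured step involves a change of this kind, so no step bears on it directly, and the step from compound 3 can only be judged against the scatter of a value that is itself a limit. The expected step is estimated as a number no higher from compound 3 to compound 4 (the limit leaves the size open), with no direction readable beyond the scatter. Compound 4 is expected to give about 350000 nM in this assay, within 100000 nM to 1000000 nM, and most probably to be reported again as a limit rather than a number.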

Compound 4, half-maximal inhibitory concentration: 354000 nM
Beside the measured number, compound 4's estimate is 1.0-fold (0.00 log units) below it; the range from low to high includes it.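

No new step can be read between compound 3 and compound 4, which carries prop-1-yn-1-yl in place of cyclopropyl. In this assay compound 3 gives > 350000 nM, a limit and not a number. The compounds shown leave open whether any change on this saturated ring carbon shifts the read-out, and by how much.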